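The compounds below may be only part of what the source reports. "The series", "measured", "known", "first", "only" and "open" are said of these compounds alone.

For the measured compounds named here, compound 1, with the structure `CC1CCN(C2CCN(S(=O)(=O)c3ccc(C#N)cc3)CC2)CC1`, is one of two compounds measured in a functional assay on DLD-1 cells (Homo sapiens) for antiproliferative activity, read by CellTiter-Glo, with a stated time of 72 h; a lower number here means a stronger inhibitor, a higher number a weaker inhibitor. In this assay compound 1 gives 2800 nM, the higher of the two numbers and therefore the weaker result. Going by the values given here, its only measured neighbour is compound 2, with the structure `CC1CCN(C2CCN(S(=O)(=O)c3ccc(-c4ccc(Cl)cc4)cc3)CC2)CC1`, which in this assay gives 105 nM. Among the compounds with values here, the single step between them, a 27-fold lower number from compound 1 to compound 2 (1.43 log units; beyond the scatter), is large and lies well beyond the scatter.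

Compound 3, with the structure `CC1CCN(C2CCN(S(=O)(=O)c3cc(Cl)cc(Cl)c3)CC2)CC1`, has not yet been measured. Compared with compound 1 it differs in one place: 3,5-dichlorophenyl in place of 4-cyanophenyl on a sulfonyl sulfur. Within the data shown here, the one measured step that bears on this change is the step from compound 1 to compound 2, where replacing the cyano group with 4-chlorophenyl lowered the number sharply. The change to compound 3 also removes the cyano group and puts chlorine onto the aromatic ring, though without adding a second ring, so a smaller step in the same direction is expected. Compound 3 is estimated to give 600 nM in this assay, with a likely range from 200 nM to 2000 nM. This corresponds to an expected step of a 4.7-fold lower number from compound 1 to compound 3 (0.67 log units; beyond the scatter).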

Compound 3, half-maximal inhibitory concentration: 3400 nM
The estimate for compound 3 lay 5.7-fold (0.75 log units) below the measured number; the whole stated range lies below it.
By their numbers in this assay, from the lowest: compound 2; then compounds 1 and 3 (each within the scatter of the next).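

In this assay, putting 3,5-dichlorophenyl in place of 4-cyanophenyl on the sulfonyl sulfur gives a 1.2-fold higher number from compound 1 to compound 3 (0.08 log units; within the scatter) and so leaves the number effectively unchanged. Losing the nitrile and adding chlorine to the ring are therefore not enough on their own to reproduce the large drop seen in a 27-fold lower number from compound 1 to compound 2 (1.43 log units; beyond the scatter) and that drop appears only with the 4-chlorophenyl group, which brings a second aromatic ring onto the core of compound 1. No measurement shown here explains why the two groups on the sulfonyl sulfur cannot be told apart or why the 4-chlorophenyl step is so much larger.

Going by these compounds, it remains open whether the second aromatic ring alone is enough, or whether the chlorine on it also matters, which an unsubstituted phenyl in place of the 4-chlorophenyl group of compound 2 would help to separate. On these data alone, it is also open how this assay would respond if that second ring carried an amine or a carboxylic acid instead of chlorine.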